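A few compounds are considered here, and "the series" means these few. Any claim that something is new, unique, unknown or untested is made for them only; others in the source may bear on it.

The three measured compounds share one core and differ only in one attached group. Compound 1 `Cc1cc(O)c(C(C)C)cc1-c1cc(-c2ccccc2)c(C#N)c(=O)[nH]1` is the simplest of them, and in a functional assay for inhibition, tested at 40 ug/mL (a lower number here means a weaker effect, a higher number a stronger effect of the compound at the concentration tested), compound 1 gives 29%. Compound 2 `COc1cccc(-c2cc(-c3cc(C(C)C)c(O)cc3C)[nH]c(=O)c2C#N)c1` gives 30%, and compound 3 `COc1ccc(-c2cc(-c3cc(C(C)C)c(O)cc3C)[nH]c(=O)c2C#N)cc1` gives 35%. Adding a methoxy changed little: a number 1 percentage points higher from compound 1 to compound 2 (within the scatter) and a number 6 percentage points higher from compound 1 to compound 3 (within the scatter), and moving it from one position to another, a number 5 percentage points higher from compound 2 to compound 3 (within the scatter). Compound 3 thus holds the highest of the three numbers, yet its gaps to compound 2 and to compound 1 both lie within the scatter, so the three cannot be told apart.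

Compound 4 `Cc1cc(O)c(C(C)C)cc1-c1cc(-c2ccco2)c(C#N)c(=O)[nH]1` takes a different kind of step: furan-2-yl in place of 4-methoxyphenyl on an aromatic carbon. Among the measured compounds shown here, none of the measured steps bears on exchanging a six-membered aromatic ring of carbon only for a five-membered aromatic ring with one hetero atom; the steps seen only touched a methoxy, and all of them stayed within the scatter. With no guide, the expectation for compound 4 is a step of a number 5 percentage points lower from compound 3 to compound 4 (within the scatter) in this assay, not beyond the scatter. Compound 4 is therefore estimated at 30%, with a range from 15% to 45%.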

Compound 4, a percentage reported as inhibition, at one concentration (the size of the read-out at that concentration, not a potency): 42.5%
For compound 4 the middle estimate is 12.5 percentage points below the measured one; the range from low to high includes it.
By their numbers in this assay, from the lowest: compounds 1, 2, 3 and 4 (each within the scatter of the next, the first and the last beyond it).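

In this assay, among the compounds shown here, the furan-2-yl group gives the first steps at this position that pass beyond the scatter, with a number 13.5 percentage points higher from compound 1 to compound 4 (beyond the scatter) when it replaces phenyl and a number 12.5 percentage points higher from compound 2 to compound 4 (beyond the scatter) when it replaces 3-methoxyphenyl. The same exchange against 4-methoxyphenyl gives only a number 7.5 percentage points higher from compound 3 to compound 4 (within the scatter) and so does not separate those two compounds. No measurement at hand explains why the five-membered ring gives these steps.

The compounds shown leave open whether the gain belongs to the furan oxygen or simply to a five-membered aromatic ring, which a thiophene at this position could help to separate. They also leave open how an amine or a carboxylic acid would behave here, and a read-out at one concentration says nothing about potency.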